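Swapping the aryl on the ring nitrogen of compound 3

The compounds below may be only part of what the source reports. "The series", "measured", "known", "first", "only" and "open" are said of these compounds alone.

Measured compounds:
- compound 1 `Nc1scc(CN2CCN(c3ccccc3C(F)(F)F)CC2)c1C(=O)c1ccc(Cl)cc1` gives -60% in a functional assay on CHO cells with adenosine receptor A1 (Homo sapiens) as the target, read by cAMP accumulation and immunoassay, with a stated time of 6 min, tested at 10 uM; a lower number here means a stronger effect, a higher number a weaker effect of the compound at the concentration tested
- compound 2 `Nc1scc(CN2CCN(c3ccc(Cl)c(C(F)(F)F)c3)CC2)c1C(=O)c1ccc(Cl)cc1` gives -60% in this assay
- compound 3 `Nc1scc(CN2CCN(c3ccc(C(F)(F)F)cc3)CC2)c1C(=O)c1cccc(C(F)(F)F)c1` gives -47% in this assay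

Compound 3 stands highest of the three numbers; compound 1 and compound 2 each lie lower by a gap beyond the scatter, while compound 1 and compound 2 themselves agree within it. Compound 4 `Nc1scc(CN2CCN(c3cccc(F)c3)CC2)c1C(=O)c1cccc(C(F)(F)F)c1` is not yet measured. It differs from compound 3 in one place: 3-fluorophenyl in place of 4-(trifluoromethyl)phenyl on an amine nitrogen in a ring.

Among the measured compounds shown here, the one measured step that bears on this change is no change at the digits printed from compound 1 to compound 2 (within the scatter), which also exchanged the aryl group on the amine nitrogen of the ring and left the number where it was. On that basis the step of a number 3 percentage points lower from compound 3 to compound 4 (within the scatter) is expected to stay within the scatter, with no direction favoured. Compound 4 is therefore estimated at -50%, with a range from -66% to -34%.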

Compound 4, a percentage reported as activity, at one concentration (the size of the read-out at that concentration, not a potency): -62%
Beside the measured number, compound 4's estimate is 12 percentage points above it, and the stated range covers the measured number.
By their numbers in this assay, from the lowest: compounds 4, 1 and 2 (each within the scatter of the next); then compound 3.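

In this assay, 3-fluorophenyl in place of 4-(trifluoromethyl)phenyl on the ring nitrogen gives a number 15 percentage points lower from compound 3 to compound 4 (beyond the scatter) and so moves the number by more than the usual scatter. The earlier aryl exchange at this nitrogen gave no change at the digits printed from compound 1 to compound 2 (within the scatter) and left the read-out unchanged, so the new step shows that the choice of aryl group here can matter, at least in the setting of compound 3. Nothing measured here explains why this exchange shifts the number while the earlier one did not.

This step changes both the substituent and its printed ring position, and the compounds shown cannot separate those two changes. They also leave open how an unsubstituted phenyl, 4-fluorophenyl, 3-(trifluoromethyl)phenyl or a phenyl carrying an amine would behave on this nitrogen.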